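Aryl swap on the ring amide nitrogen of compound 3

The source may hold more compounds than are shown below. What is called first, only, known or untested is meant among the compounds shown, and "the series" means these compounds.

Compound 1: `CC(C)[C@@H]1CC[C@@H](C)C[C@@]12N(C)C(=O)[C@@H]1[C@H]3C(=O)NC(=O)[C@H]3ON12`, 57.2%
Compound 2: `CC(C)[C@@H]1CC[C@@H](C)C[C@@]12N(C)C(=O)[C@@H]1[C@H]3C(=O)N(C)C(=O)[C@H]3ON12`, 59.9%
Compound 3: `CC(C)[C@@H]1CC[C@@H](C)C[C@@]12N(C)C(=O)[C@@H]1[C@H]3C(=O)N(c4ccc(Cl)cc4)C(=O)[C@H]3ON12`, 49.4%

Of the compounds shown here, three on a shared core have been measured in a functional assay, read by spectrophotometry, with a stated time of 2 h, tested at 2 mg/mL; a lower number here means a weaker effect, a higher number a stronger effect of the compound at the concentration tested. Compound 1 gives 57.2%, compound 2 gives 59.9% and compound 3 gives 49.4%. Compound 3 holds the lowest number of the three; its nearest neighbour is compound 1, with the step of a number 7.8 percentage points lower from compound 1 to compound 3 (within the scatter), and its furthest is compound 2, with the step of a number 10.5 percentage points lower from compound 2 to compound 3 (beyond the scatter). The step of a number 2.7 percentage points higher from compound 1 to compound 2 (within the scatter) shows how little a small change at this nitrogen moved this assay.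

Compound 4, `Cc1cccc(N2C(=O)[C@H]3[C@H](ON4[C@@H]3C(=O)N(C)[C@@]43C[C@H](C)CC[C@H]3C(C)C)C2=O)c1`, differs from compound 3 in one place: 3-methylphenyl in place of 4-chlorophenyl on an amide-type nitrogen in a ring. For the measured compounds named here, no measured step touches an aryl-to-aryl exchange at this nitrogen; the two aryl-bearing steps from compound 1 and compound 2 to compound 3 are the only guide, one within and one just beyond the scatter. As the group entering and the group leaving are of like size, the step of a number 1.6 percentage points higher from compound 3 to compound 4 (within the scatter) is expected to remain within the scatter. Compound 4 is therefore estimated at 51%, in the range 39% to 63%.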

Compound 4, a percentage reported as activity, at one concentration (the size of the read-out at that concentration, not a potency): 35.3%
Beside the measured number, compound 4's estimate is 15.7 percentage points above it, and the stated range ends above it.
By their numbers in this assay, from the lowest: compound 4; then compounds 3, 1 and 2 (each within the scatter of the next, the first and the last beyond it).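

In this assay, replacing one aryl group with another at this amide-type nitrogen proved far from neutral: 3-methylphenyl in place of 4-chlorophenyl gives a number 14.1 percentage points lower from compound 3 to compound 4 (beyond the scatter), even though the two groups have the same counts of heavy atoms, aromatic rings, hydrogen-bond donors and hydrogen-bond acceptors. Compound 4 also lies clearly under both compounds with a small group at this nitrogen, with a number 24.6 percentage points lower from compound 2 to compound 4 (beyond the scatter) and a number 21.9 percentage points lower from compound 1 to compound 4 (beyond the scatter), so the read-out depends on which aryl group is present and not only on whether an aryl group is there. Nothing available bears on why the read-out responds to this exchange.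

The exchange alters both the ring substituent, chlorine against methyl, and the number of the ring position that carries it, so compound 3 and compound 4 cannot show which of the two alterations accounts for the step. It also remains open where an unsubstituted phenyl or a benzyl group at this nitrogen would fall in this assay, and whether the order of these compounds would hold at other concentrations.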